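The source may report more compounds than this note shows. Statements on the series, on what has been measured and on what is new or still open speak of the compounds shown alone.

Compound 1 `CCOC(=O)C1=Cc2ccccc2OC1(OCc1cn(-c2ccc(F)c([N+](=O)[O-])c2)nn1)C(F)(F)F`: 13200 nM
Compound 2 `CCOC(=O)C1=Cc2ccccc2OC1(OCc1cn(CC(=O)Nc2ccccc2F)nn1)C(F)(F)F`: 33900 nM

For the measured compounds named here, in a functional assay on DU-145 cells (Homo sapiens) for inhibition, read by MTT assay, with a stated time of 24 h (a lower number here means a stronger inhibitor, a higher number a weaker inhibitor), compound 2 gives the higher of the two numbers so far. Going by the values given here, the single measured step, a 2.6-fold higher number from compound 1 to compound 2 (0.41 log units; beyond the scatter), is modest, and it alters the aromatic nitrogen rather than the amide-type nitrogen. Among the compounds with values here, compound 3 `CCOC(=O)C1=Cc2ccccc2OC1(OCc1cn(CC(=O)Nc2cccc(F)c2)nn1)C(F)(F)F` differs from compound 2 by 3-fluorophenyl in place of 2-fluorophenyl on an amide-type nitrogen, a change for which no measured step offers direct guidance. The expected step is therefore a 1.1-fold lower number from compound 2 to compound 3 (0.05 log units; within the scatter), nothing beyond the scatter. Compound 3 is estimated at 30000 nM, with a range from 12000 nM to 75000 nM.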

Compound 3, half-maximal inhibitory concentration: > 150000 nM
Compound 3: only a limit was reported; the forecaster's own chance of this, stated with the estimate: 8%; middle value at least 5.0-fold (0.69 log units) from the limit.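

In this assay compound 3 gives > 150000 nM, which is a limit of the assay and not a number. On the amide-type nitrogen, 3-fluorophenyl in place of 2-fluorophenyl keeps the same atoms yet gives an at least 4.4-fold higher number from compound 2 to compound 3 (0.64 log units; beyond the scatter), so this site responds to how the ring is joined, not only to which atoms are present. The change on the aromatic nitrogen now reads as an at least 11-fold higher number from compound 1 to compound 3 (1.05 log units; beyond the scatter), larger than the modest step seen earlier.

Going by these compounds, the true value of compound 3 stays unknown. Also open, on these data alone, is how a plain phenyl, a 4-fluorophenyl or a chlorophenyl would behave on that amide-type nitrogen.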